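Shortening the saturated chain on the ring carbon

This account rests on a few compounds, and the source may have more. Where it says the series, first, only, none or still open, it means among the compounds named here.

Working notes on the series. In a functional assay on MV cells (Homo sapiens) for inhibition, read by sulforhodamine B assay (a lower number here means a stronger inhibitor, a higher number a weaker inhibitor), compound 1 `C#CC(=O)N1C(c2ccc(C#N)cc2)SC[C@@H]1C(=O)OCC` gives 2400 nM, compound 3 `C#CC(=O)N1C(c2ccc(OC)cc2)SC[C@@H]1C(=O)OCC` gives 700 nM, and compound 2 `C#CC(=O)N1C(C(CC)CCCC)SC[C@@H]1C(=O)OCC` gives 1600 nM. Among the measured compounds shown here, the one single-point step among the measured compounds is a 3.4-fold lower number from compound 1 to compound 3 (0.54 log units; beyond the scatter). Compound 2 stands second highest of the three numbers: its gap to compound 1 lies within the scatter, while its gap to compound 3 lies beyond the scatter, with compound 3 on the lower side.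

Compound 4 `C#CC(=O)N1C(CCCC)SC[C@@H]1C(=O)OCC` differs from compound 2 by butyl in place of 1-ethylpentyl on a saturated ring carbon. For the measured compounds named here, the measured step concerns the substituent on the aromatic ring of compound 1 and compound 3 and leaves the saturated chain untouched, so no measured step bears directly on this change. Compound 2 with its 1-ethylpentyl group sits between compound 1 and compound 3 without a difference beyond the scatter from compound 1, and the measured compounds give no direction for a shorter chain. The expected step is therefore a 1.1-fold higher number from compound 2 to compound 4 (0.05 log units; within the scatter), no more than the usual scatter. For compound 4 the estimated value in this assay is 1800 nM, with a range from 800 nM to 4500 nM.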

Compound 4, half-maximal inhibitory concentration: 400 nM
The estimate for compound 4 lay 4.5-fold (0.65 log units) above the measured number, and the stated range ends above it.
By their numbers in this assay, from the lowest: compounds 4 and 3 (each within the scatter of the next); then compounds 2 and 1 (each within the scatter of the next).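

In this assay, butyl in place of 1-ethylpentyl on the saturated ring carbon gives a 4.0-fold lower number from compound 2 to compound 4 (0.60 log units; beyond the scatter), so the number responds to the saturated group at this position, whereas the earlier step concerned only the substituent on the aromatic ring. Compound 3 at 700 nM and compound 4 at 400 nM lie within the scatter of each other, which shows that among these compounds a value of this size at this position is reached both with the methoxy-bearing aromatic ring and with butyl, a group with no ring. The compounds shown offer no measured explanation for the step from 1-ethylpentyl to butyl.

Butyl and 1-ethylpentyl differ both in the number of carbons and in the branch, so the compounds shown do not separate the effect of chain length from that of branching. An unbranched heptyl chain would address that question, while propyl, or a butyl chain ending in an amine or a carboxylic acid, would show how far this position tolerates further shortening or a different chain end.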